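A Dimethoxyphenyl in Place of the Phenylethenyl Group

A few compounds are considered here, and "the series" means these few. Any claim that something is new, unique, unknown or untested is made for them only; others in the source may bear on it.

Compound 1, `Cc1cc(O)c(C2=NN(c3ccc(S(N)(=O)=O)cc3)C(c3ccccc3O)C2)cc1Cl`, gives 3590 nM in a functional assay on SW-620 cells (Homo sapiens) for antiproliferative activity, with a stated time of 48 h; a lower number here means a stronger inhibitor of growth, a higher number a weaker inhibitor of growth.
Compound 2, `Cc1cc(O)c(C2=NN(c3ccc(S(N)(=O)=O)cc3)C(c3ccccc3Cl)C2)cc1Cl`, gives 4100 nM.
Compound 3, `Cc1cc(O)c(C2=NN(c3ccc(S(N)(=O)=O)cc3)C(/C=C/c3ccccc3)C2)cc1Cl`, gives 31300 nM.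

Compound 3 stands highest of the three. The two aryl-bearing compounds sit close together, a 1.1-fold higher number from compound 1 to compound 2 (0.06 log units; within the scatter), whereas an 8.7-fold higher number from compound 1 to compound 3 (0.94 log units; beyond the scatter) and a 7.6-fold higher number from compound 2 to compound 3 (0.88 log units; beyond the scatter). Compound 4, `COc1ccc(C2CC(c3cc(Cl)c(C)cc3O)=NN2c2ccc(S(N)(=O)=O)cc2)cc1OC`, carries the change (3,4-dimethoxyphenyl in place of 2-phenylethenyl on a saturated ring carbon). Both steps toward compound 3 bear on it, since they replace an aryl group at this carbon with the phenylethenyl group and cost a modest amount. Reversing that, compound 4 is expected to return to the level of compounds 1 and 2, so a 7.0-fold lower number from compound 3 to compound 4 (0.84 log units; beyond the scatter) is the estimated step. The expected value for compound 4 is 4500 nM, in the range 1500 nM to 14000 nM.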

Compound 4, concentration for total growth inhibition: 26600 nM
For compound 4 the middle estimate is 5.9-fold (0.77 log units) below the measured one; measured number above the stated range.
By their numbers in this assay, from the lowest: compounds 1 and 2 (each within the scatter of the next); then compounds 4 and 3 (each within the scatter of the next).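

An aryl group on this saturated ring carbon does not by itself keep the number low in this assay: 3,4-dimethoxyphenyl in place of 2-phenylethenyl gives a 1.2-fold lower number from compound 3 to compound 4 (0.07 log units; within the scatter). Set against the aryl groups of the earlier compounds, 3,4-dimethoxyphenyl costs a modest amount, with a 6.5-fold higher number from compound 2 to compound 4 (0.81 log units; beyond the scatter) and a 7.4-fold higher number from compound 1 to compound 4 (0.87 log units; beyond the scatter). No measurement at hand explains this loss.

The compounds shown leave open whether both methoxy groups are needed for the loss or one alone would give it. They also do not show how a phenyl group bearing a single methoxy group or an amine would behave at this carbon.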